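The compounds below may be only part of what the source reports. "The series", "measured", "known", "first", "only" and "open" are said of these compounds alone.

Compound 1 `O=c1ccoc2cc(OCc3cn(Cc4cccc(F)c4)nn3)ccc12` in a functional assay on HeLa cells (Homo sapiens) for cytotoxicity, read by MTT assay, with a stated time of 48 h (a higher number here means a weaker inhibitor, a lower number a stronger inhibitor), gives 7550 nM and stands as the lowest of the two numbers shown. Compound 2 `O=c1ccoc2cc(OCc3cn(Cc4ccccc4Br)nn3)ccc12` gives 14500 nM in this assay, a step of a 1.9-fold higher number from compound 1 to compound 2 (0.28 log units; within the scatter). Compound 3 `O=c1ccoc2cc(OCc3cn(Cc4cccc(Br)c4)nn3)ccc12` gives only a limit in this assay, > 100000 nM. From it follow the steps of an at least 13-fold higher number from compound 1 to compound 3 (1.12 log units; beyond the scatter) and an at least 6.8-fold higher number from compound 2 to compound 3 (0.83 log units; beyond the scatter), and the limit of > 100000 nM in this assay, at which 1 of the 3 values shown sits, means the true size of each may be larger. Compound 4 `N#Cc1cccc(Cn2cc(COc3ccc4c(=O)ccoc4c3)nn2)c1` differs from compound 1 by cyano in place of fluoro on an aromatic carbon. Among the measured compounds shown here, the one step at this same aromatic carbon, an at least 13-fold higher number from compound 1 to compound 3 (1.12 log units; beyond the scatter), was a large loss; cyano is not bromo, so a smaller loss is expected, a 2.4-fold higher number from compound 1 to compound 4 (0.38 log units; beyond the scatter). Compound 4 is therefore estimated at 18000 nM, within 5000 nM to 70000 nM.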

Compound 4, half-maximal inhibitory concentration: > 100000 nM
Compound 4 gave a limit, no number; the forecaster's own chance of this, stated with the estimate: 20%; at least 5.5-fold (0.74 log units) between middle value and limit.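

In this assay the loss at this aromatic carbon is no longer tied to bromo, since cyano in place of fluoro also gives an at least 13-fold higher number from compound 1 to compound 4 (1.12 log units; beyond the scatter). 3-Cyanophenyl in place of 2-bromophenyl likewise costs, with an at least 6.8-fold higher number from compound 2 to compound 4 (0.83 log units; beyond the scatter). The step between compound 3 and compound 4 cannot be read, and the other sizes are bounds only, as each rests on a limit and not a number: the limit of > 100000 nM in this assay, at which 2 of the 4 values shown sit.

Left open is whether an amine or a methoxy group on this aromatic carbon would stay close to compound 1. Also open, going by these compounds, is what compound 3 and compound 4 would read beyond their limits.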